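The compounds below may be only part of what the source reports. "The series", "measured", "known", "first", "only" and "open" are said of these compounds alone.

Within the data shown here, in an ADME assay on MT4 cells (Homo sapiens) for cytotoxicity, read by MTT assay, with a stated time of 5 days (on this read-out lower numbers stand for higher toxicity in this test and higher numbers for lower toxicity in this test), compound 1 (`Cc1cc(C)cc(S(=O)(=O)c2c(C(N)=O)[nH]c3ccc(Cl)cc23)c1`) gives 13000 nM and is the only compound in this pair with an exact number. Compound 2 (`Cc1cc(C)cc(S(=O)(=O)c2c(C(=O)NC3CN(Cc4ccccc4F)C3)[nH]c3ccc(Cl)cc23)c1`) reports > 238000 nM in this assay and this is a limit, not a number, so compound 2 has no exact place on the scale. Among the measured compounds shown here, the only measured step is an at least 18-fold higher number from compound 1 to compound 2 (1.26 log units; beyond the scatter) and it comes with 1-(2-fluorobenzyl)azetidin-3-yl in place of hydrogen on an amide-type nitrogen.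

Compound 3 (`Cc1cc(C)cc(S(=O)(=O)c2c(C(=O)NS(=O)(=O)c3ccc(F)cc3)[nH]c3ccc(Cl)cc23)c1`) is not yet measured. It carries (4-fluorophenyl)sulfonyl in place of 1-(2-fluorobenzyl)azetidin-3-yl on an amide-type nitrogen. For the measured compounds named here, no measured step covers the entering group, so the sole guide is that compound 3 gives up the group that came with an at least 18-fold higher number from compound 1 to compound 2 (1.26 log units; beyond the scatter) as its only measured change. A large step to a lower number, meaning higher toxicity, is therefore expected in this assay and the size remains uncertain. The expected move is an at least 5.9-fold lower number from compound 2 to compound 3 (0.77 log units; beyond the scatter) on this estimate. Compound 3 is estimated at 40000 nM with an expected range from 10000 nM to 200000 nM in this read-out.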

Compound 3, half-maximal cytotoxic concentration: > 252000 nM
Compound 3: only a limit was reported; the forecaster's own chance of this, stated with the estimate: 20%; at least 6.3-fold (0.79 log units) between middle value and limit.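

In this assay compound 3 reports > 252000 nM, and this is a limit, not a number. On the amide-type nitrogen, (4-fluorophenyl)sulfonyl in place of hydrogen goes with an at least 19-fold higher number from compound 1 to compound 3 (1.28 log units; beyond the scatter), so a higher number at this position no longer rests on 1-(2-fluorobenzyl)azetidin-3-yl alone, and the four-membered non-aromatic ring with its nitrogen is not required for it among the compounds shown. The step between compound 2 and compound 3 cannot be read, as each of the two values is a limit, and neither substituent can be ranked against the other.

Both substituents shown carry a six-membered aromatic ring of carbon only and a fluorine, so it remains open whether a methyl group or a simple alkyl chain on the same nitrogen, with neither feature, would also give a higher number than the unsubstituted amide. Any real difference between 1-(2-fluorobenzyl)azetidin-3-yl and (4-fluorophenyl)sulfonyl also remains open on this read-out.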